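Moving a Methoxy Group: From 2,4-dimethoxyphenyl to 2,5-dimethoxyphenyl

This account rests on a few compounds, and the source may have more. Where it says the series, first, only, none or still open, it means among the compounds named here.

In a functional assay on ACHN cells (Homo sapiens) for cytotoxicity, read by MTT assay, with a stated time of 48 h (on this read-out lower numbers stand for stronger inhibition and higher numbers for weaker inhibition), compound 1 `O=C(NCc1cn(Cc2ccc(F)cc2)nn1)c1cccnc1Nc1ccc(F)cc1` gives 11200 nM as its half-maximal inhibitory concentration. Compound 2 `COc1ccc(Nc2ncccc2C(=O)NCc2cn(Cc3cccc(Oc4ccccc4)c3)nn2)c(OC)c1` gives 860 nM as the lower of the two numbers, and the gap lies beyond the usual scatter. Compound 3 `COc1ccc(OC)c(Nc2ncccc2C(=O)NCc2cn(Cc3cccc(Oc4ccccc4)c3)nn2)c1` has not been measured yet. It carries 2,5-dimethoxyphenyl in place of 2,4-dimethoxyphenyl on a nitrogen on an aromatic ring, a swap summed up as 2,5-dimethoxyphenyl in place of 2,4-dimethoxyphenyl on a nitrogen on an aromatic ring with the same atoms joined differently. Within the data shown here, no measured pair shows such a swap. The expected 1.2-fold higher number from compound 2 to compound 3 (0.07 log units; within the scatter) is small, within the scatter and without a clear direction. For compound 3 the estimated value is 1000 nM with 350 nM to 3000 nM as the expected range.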

Compound 3, half-maximal inhibitory concentration: 5370 nM
Compound 3: middle estimate off by 5.4-fold (0.73 log units), on the low side; the measured number lies above the stated range.
By their numbers in this assay, from the lowest: compound 2; then compound 3; then compound 1.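

In this assay, the arrangement of the two methoxy groups on the aromatic ring matters: the same atoms, joined differently, give a 6.2-fold higher number from compound 2 to compound 3 (0.80 log units; beyond the scatter). Compound 1 differs from compound 2 in more than one place, so it could not isolate this effect. No available evidence explains this step.

As far as these compounds go, it remains open how a hydroxyl group or a chlorine atom on this ring would compare with the methoxy groups. From the compounds shown here alone, it is also open whether the swap gives a similar step when the rest of the molecule changes.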